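Solubility notes: thiophene to phenyl on the shared core

The source may report more compounds than this note shows. Statements on the series, on what has been measured and on what is new or still open speak of the compounds shown alone.

Compound 1 `CCOC(=O)c1c(-c2ccc(OC)cc2)[nH]c2cccc(OC)c2c1=O` and compound 2 `CCOC(=O)c1c(-c2cccs2)[nH]c2cc(OC)ccc2c1=O` share a core bearing an ethoxycarbonyl group. In a physicochemical assay for solubility, in phosphate buffer, at pH 7.4 (on this read-out lower numbers stand for lower solubility and higher numbers for higher solubility), compound 1 gives a limit of the assay rather than a number, > 100000 nM. In this assay compound 2 likewise returns only a limit, > 100000 nM. Where compound 2 stands can thus be stated only as that limit; both values recorded so far sit at it (the limit of > 100000 nM in this assay, at which 2 of the 2 values shown sit), so no ordering between compound 1 and compound 2 follows.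

Compound 3 `CCOC(=O)c1c(-c2ccccc2)[nH]c2cc(OC)ccc2c1=O` differs from compound 2 in one place (phenyl in place of thiophen-2-yl on an aromatic carbon). Going by the values given here, no measured step between two compounds exists, so the size of the change cannot be read from a neighbour. Compound 2 sits at the limit in this assay, > 100000 nM. On that basis the step is expected to be a number no higher from compound 2 to compound 3 (the limit leaves the size open), none beyond the scatter. For compound 3 the expected solubility in this assay is 100000 nM, with a range from 40000 nM to 200000 nM, most likely reported again only as a limit.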

Compound 3, solubility: > 100000 nM
Compound 3 ended at the assay's limit; the forecaster's own chance of this, stated with the estimate: 80%; the middle value sits exactly at the limit.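

No step from compound 2 to compound 3 can be read in this assay, because each compound returns only a limit of the assay, so swapping thiophen-2-yl for phenyl gives no measurable size: the limit of > 100000 nM in this assay, at which 3 of the 3 values shown sit.

The compounds shown leave open where compound 1, compound 2 and compound 3 truly lie relative to one another, and whether phenyl and thiophen-2-yl differ at all on the shared core.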